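Changing One Amide Substituent in a Cytotoxicity Series

A few compounds are considered here, and "the series" means these few. Any claim that something is new, unique, unknown or untested is made for them only; others in the source may bear on it.

Compound 1 `COc1cc([C@@H]2C[C@@]2(CO)C(=O)NCc2ccc(C)cc2)cc(OC)c1OC` and compound 2 `COc1cc([C@H]2C[C@@]2(CO)C(=O)Nc2ccccc2Cl)cc(OC)c1OC` have both been tested in a functional assay on HeLa cells (Homo sapiens) for cytotoxicity, read by MTT assay, with a stated time of 48 h; on this read-out higher numbers stand for weaker inhibition and lower numbers for stronger inhibition. Compound 1 gives 41200 nM there. Compound 2 gives > 100000 nM, which is a limit of the assay and not a number, so it has no exact place on the scale.

Compound 3 `COc1cc([C@H]2C[C@@]2(CO)C(=O)NCc2ccc(C)cc2)cc(OC)c1OC` has not been measured yet. Going from compound 2 to compound 3 places 4-methylbenzyl in place of 2-chlorophenyl on an amide-type nitrogen. Compound 1 also carries 4-methylbenzyl in that place and gives 41200 nM, so a value close to that one seems a fair expectation. Going by these compounds, the estimated step is an at least 2.5-fold lower number from compound 2 to compound 3 (0.39 log units; beyond the scatter), in the direction of stronger inhibition, though its true size stays open. For compound 3 the expected value is 40000 nM, with an estimated range of 12000 nM to 100000 nM.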

Compound 3, half-maximal inhibitory concentration: > 100000 nM
Compound 3: a limit, no number; the forecaster's own chance of this, stated with the estimate: 25%; middle value at least 2.5-fold (0.39 log units) from the limit.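

In this assay, among these compounds, the one comparison that can be read here concerns stereochemistry, not the amide substituent, with an at least 2.4-fold higher number from compound 1 to compound 3 (0.38 log units; beyond the scatter). The 4-methylbenzyl group alone therefore does not fix the read-out, and this gap can be traced to the single stereocentre at the saturated ring carbon, drawn S in compound 1 and R in compound 3: the fact that compounds 1 and 3 differ only in the configuration as drawn. The step for replacing 2-chlorophenyl with 4-methylbenzyl cannot be read, as compound 2 and compound 3 both stand at a limit of the assay and not at a number: the limit of > 100000 nM in this assay, at which 2 of the 3 values shown sit.

Going by these compounds, it remains open whether 2-chlorophenyl on the amide-type nitrogen would give a measurable value with the stereocentre drawn as in compound 1. The compounds shown also say nothing about an unsubstituted benzyl group in that place.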